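The source may hold more compounds than are shown below. What is called first, only, known or untested is meant among the compounds shown, and "the series" means these compounds.

In a functional assay on the whole organism (Abdomen, strain Swiss) for inhibition, with Mus musculus as the target, with stated times of 30 min, 10 min and 5 min, at a dose of 20 mg/kg by the oral route (a higher number here means a stronger effect of the compound at the dose given, a lower number a weaker effect), the measured compounds stand as follows:

Compound 1, `Cc1c(C#N)c(-c2ccccc2)nn1CCCN1CCN(c2cccc(Cl)c2)CC1`, gives 0%.
Compound 2, `COc1cccc(N2CCN(CCCn3nc(-c4ccccc4)c(C#N)c3C)CC2)c1`, gives 21%.
Compound 3, `O=c1occ(-c2ccccc2)n1CCCN1CCN(c2cccc(Cl)c2)CC1`, gives 31%.

Compound 2 arises from compound 1 by methoxy in place of chloro on an aromatic carbon, and this change made a step of a number 21 percentage points higher from compound 1 to compound 2 (beyond the scatter) in this assay. The difference between the core of compound 3 and the core of compound 1 is not broken down here; their values in this assay simply differ as shown. Compound 4, `COc1cccc(N2CCN(CCCn3c(-c4ccccc4)coc3=O)CC2)c1`, is related to compound 3 by the same kind of change, (methoxy in place of chloro on an aromatic carbon), at a place described in the same words. Because compound 1 to compound 2 gave a number 21 percentage points higher from compound 1 to compound 2 (beyond the scatter), compound 4 is expected to show a step of a number 17 percentage points higher from compound 3 to compound 4 (beyond the scatter) in this assay, resting on that single earlier occurrence. Compound 4 is therefore estimated at 48%, between 25% and 70%.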

Compound 4, a percentage reported as inhibition, in the whole organism at one dose (the size of the read-out at that dose, not a potency): 25%
For compound 4 the middle estimate is 23 percentage points above the measured one; measured number inside the range.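

In this assay, methoxy in place of chloro gave a number 6 percentage points lower from compound 3 to compound 4 (within the scatter). Set beside the earlier occurrence, the same change did not behave alike on the two cores: the same change on two cores in this assay, a number 21 percentage points higher (beyond the scatter) from compound 1 to compound 2 and a number 6 percentage points lower (within the scatter) from compound 3 to compound 4, 27 percentage points apart, beyond the scatter of two such steps This shows that the rise seen on the core of compound 1 cannot simply be carried over to the core of compound 3, but with only two pairs it gives no reason for the difference and no rule for any other core.

Going by these compounds, what a fluoro or a methyl group would do at the same place on either core remains open. So does the effect of a longer chain on these two cores.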